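The compounds below may be only part of what the source reports. "The series", "measured", "known", "first", "only" and "open" are said of these compounds alone.

In a functional assay on NB-4 cells (Homo sapiens) for inhibition, read by XTT assay, with a stated time of 48 h (on this read-out lower numbers stand for stronger inhibition and higher numbers for weaker inhibition), compound 1 (`COc1ccc(C(=O)/C(=C/C2CCCCC2)COC(=O)c2ccccc2)cc1`) gives 10200 nM and lies within the scatter of both other measured compounds: compound 2 (`C/C=C(\COC(=O)c1ccccc1)C(=O)c1ccc(OC)cc1`) gives 16200 nM and compound 3 (`COc1ccc(C(=O)/C(=C/c2ccccc2Cl)COC(=O)c2ccccc2)cc1`) gives 7000 nM in the same test. Compound 4 (`COc1ccc(C(=O)/C(=C/C2CCCCC2)CC(C)OC(C)=O)cc1`) differs from compound 1 by 1-acetoxyethyl in place of benzoyloxy on a saturated chain carbon bound to a double-bonded chain carbon. The measured steps all lie at another place, so none tests this change directly. They are small, with a 1.6-fold higher number from compound 1 to compound 2 (0.20 log units; within the scatter) and a 1.5-fold lower number from compound 1 to compound 3 (0.16 log units; within the scatter) inside the scatter and a 2.3-fold lower number from compound 2 to compound 3 (0.36 log units; beyond the scatter) modestly beyond it. Going by those sizes, no step beyond the scatter is expected in this assay in either direction, and the expected step is a 1.2-fold higher number from compound 1 to compound 4 (0.07 log units; within the scatter) as a rough estimate. Compound 4 is estimated at 12000 nM with an expected range from 5000 nM to 30000 nM as its span.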

Compound 4, half-maximal inhibitory concentration: 33400 nM
Estimate against measurement, compound 4: 2.8-fold (0.44 log units) below; measured number outside the range, above it.
By their numbers in this assay, from the lowest: compounds 3, 1 and 2 (each within the scatter of the next, the first and the last beyond it); then compound 4.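

In this assay the exchange of benzoyloxy for 1-acetoxyethyl on a saturated chain carbon bound to a double-bonded chain carbon (a 3.3-fold higher number from compound 1 to compound 4 (0.52 log units; beyond the scatter)) goes beyond the scatter and weakens inhibition. Going by these compounds alone, this place therefore responds more than the earlier steps at the other place suggested, and the change removes an aromatic ring. Nothing at hand gives a reason for this step.

Going by these compounds, it remains open whether an amine or a carboxylic acid here would read differently, and whether this step holds with methyl or 2-chlorophenyl in place of cyclohexyl.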